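Swapping the Sulfonyl Aryl Ring: From Fluoro to Dichloro

The compounds below may be only part of what the source reports. "The series", "measured", "known", "first", "only" and "open" are said of these compounds alone.

Of the compounds shown here, three built on one shared core have been tested in an assay on isolated protein for displacement of a labelled ligand from metabotropic glutamate receptor 5 (Homo sapiens), with a stated time of 60 min, tested at 1 uM; a lower number here means less inhibition, a higher number more inhibition at the concentration tested (going by the name of the read-out). Compound 1 `COc1ccc2ncc(S(=O)(=O)c3cccc(C#N)c3)c(N3CCC(C)CC3)c2c1` gives 90%, compound 2 `COc1ccc2ncc(S(=O)(=O)c3ccc(C)cc3)c(N3CCC(C)CC3)c2c1` gives 90%, and compound 3 `COc1ccc2ncc(S(=O)(=O)c3ccc(F)cc3)c(N3CCC(C)CC3)c2c1` gives 27%. Compound 3 therefore stands lowest of the three, as shown by a number 63 percentage points lower from compound 1 to compound 3 (beyond the scatter) and by a number 63 percentage points lower from compound 2 to compound 3 (beyond the scatter). Between the two higher compounds, by contrast, there is no change at the digits printed from compound 1 to compound 2 (within the scatter).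

Compound 4 `COc1ccc2ncc(S(=O)(=O)c3cc(Cl)cc(Cl)c3)c(N3CCC(C)CC3)c2c1` has not yet been measured. It differs from compound 3 in a single place: 3,5-dichlorophenyl in place of 4-fluorophenyl on a sulfonyl sulfur.

The two measured steps that bear on this change both end at compound 3 and both are large: the step from a 3-cyanophenyl and the step from a 4-methylphenyl each fell by the same wide margin on arriving at the 4-fluorophenyl. They show that the group carried on the sulfonyl sulfur can move the read-out strongly, and that the 4-fluorophenyl of compound 3 is the lowest of the three aryl groups seen so far. No dichloro group has been measured, so the direction rests on this pattern alone. The step from compound 3 to compound 4 is expected to be upward and large, a number 43 percentage points higher from compound 3 to compound 4 (beyond the scatter). Compound 4 is accordingly estimated at 70%, within a range from 35% to 95%.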

Compound 4, a percentage reported as inhibition, at one concentration (the size of the read-out at that concentration, not a potency): 87%
Beside the measured number, compound 4's estimate is 17 percentage points below it; the range from low to high includes it.
By their numbers in this assay, from the lowest: compound 3; then compounds 4, 1 and 2 (each within the scatter of the next).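

On the sulfonyl sulfur, 3,5-dichlorophenyl in place of 4-fluorophenyl gives a number 60 percentage points higher from compound 3 to compound 4 (beyond the scatter) in this assay, so a halogen on this aryl ring does not by itself bring the low reading seen for compound 3. Among the compounds shown here, the other two steps, a number 3 percentage points lower from compound 2 to compound 4 (within the scatter) and a number 3 percentage points lower from compound 1 to compound 4 (within the scatter), put compound 4 level with the earlier pair, which means that three differently substituted aryl groups now give matching readings, and compound 3 is the only one of the four compounds that goes against this. Nothing measured here explains why the 4-fluorophenyl group stands apart from the other three aryl groups.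

Whether the high reading needs any substituent on this ring remains open, since the compounds shown include no unsubstituted phenyl, and none with a carboxylic acid or an amine on the ring. Readings taken at one concentration also cannot say how compounds 1, 2 and 4 would compare at other concentrations, a question that a full concentration series could address.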